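The compounds below may be only part of what the source reports. "The series", "measured", "known", "first", "only" and "open" are said of these compounds alone.

The three measured compounds share one core and differ only in the group attached to a saturated ring carbon. Compound 1 `N#CC1=C(N)OC(c2c[nH]c3ccccc23)=C(C#N)C1c1ccc(Br)cc1` carries 4-bromophenyl there, compound 2 `COc1ccc(C2C(C#N)=C(N)OC(c3c[nH]c4ccccc34)=C2C#N)cc1OC` carries 3,4-dimethoxyphenyl, and compound 3 `COc1ccc(C2C(C#N)=C(N)OC(c3c[nH]c4ccccc34)=C2C#N)cc1` carries 4-methoxyphenyl. In a functional assay, tested at 100 ug/mL (a higher number here means a stronger effect of the compound at the concentration tested, a lower number a weaker effect), compound 3 gives 20%. Compound 2 gives 19.1% and compound 1 gives 14.6%, so all three values lie within the scatter of one another and none of them can be set apart from the rest.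

Compound 4 `N#CC1=C(N)OC(c2c[nH]c3ccccc23)=C(C#N)C1c1cccc2ccccc12` changes the same saturated ring carbon once more: naphthalen-1-yl in place of 4-methoxyphenyl on a saturated ring carbon. Two kinds of measured step bear on it. The exchange of the whole group on that saturated ring carbon gave a number 4.5 percentage points higher from compound 1 to compound 2 (within the scatter), and the changes on an aromatic carbon gave a number 5.4 percentage points higher from compound 1 to compound 3 (within the scatter) and a number 0.9 percentage points higher from compound 2 to compound 3 (within the scatter). None of these moved the read-out beyond the scatter, so no step beyond the scatter is expected for compound 4 either, in either direction.

Compound 4 is therefore estimated at 20%, with a range from 8% to 33%. This estimate means an expected step of no change at the digits printed from compound 3 to compound 4 (within the scatter) in this assay.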

Compound 4, a percentage reported as activity, at one concentration (the size of the read-out at that concentration, not a potency): 6.8%
The estimate for compound 4 lay 13.2 percentage points above the measured number, outside the stated range (below it).
By their numbers in this assay, from the lowest: compounds 4, 1, 2 and 3 (each within the scatter of the next, the first and the last beyond it).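

Of the groups shown on this saturated ring carbon, only naphthalen-1-yl gives a difference beyond the scatter in this assay: putting it in place of 4-methoxyphenyl gives a number 13.2 percentage points lower from compound 3 to compound 4 (beyond the scatter), and putting it in place of 3,4-dimethoxyphenyl gives a number 12.3 percentage points lower from compound 2 to compound 4 (beyond the scatter), although the step in place of 4-bromophenyl, a number 7.8 percentage points lower from compound 1 to compound 4 (within the scatter), does not separate the two compounds. Going by these compounds alone, the position is therefore not indifferent to the group it carries, as the earlier compounds alone left possible, and the change from 4-methoxyphenyl replaces one six-membered aromatic ring of carbon only and a single hydrogen-bond acceptor with two such rings and no acceptor. Nothing shown here accounts for this difference.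

The compounds shown leave open whether the result follows from the second ring as such or from the way it is attached, a question that naphthalen-2-yl at the same carbon would address. They also leave open how this position responds to a phenyl ring carrying a dimethylamino group or a carboxylic acid.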